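The source may report more compounds than this note shows. Statements on the series, on what has been measured and on what is new or still open speak of the compounds shown alone.

In a functional assay on DU-145 cells (Homo sapiens) for cytotoxicity, read by MTT assay (on this read-out higher numbers stand for weaker inhibition and lower numbers for stronger inhibition), compound 1 `COC(=O)C[C@H]1C[C@@H](O)[C@@H](C)[C@@H](c2ccc(C(C)C)cc2)N1` gives 110000 nM, compound 2 `COC(=O)C[C@H]1C[C@@H](O)[C@@H](C)[C@@H](c2ccc(OC)cc2)N1` gives 12600 nM and compound 3 `COC(=O)C[C@H]1C[C@H](O)[C@@H](C)[C@@H](c2ccc(OC)cc2)N1` gives 6500 nM. Compound 2 therefore lies well under compound 1 and within the scatter of compound 3. Compound 4 `COC(=O)C[C@H]1C[C@@H](O)[C@@H](C)[C@@H](c2ccc(F)cc2)N1` changes one group of compound 2: fluoro in place of methoxy on an aromatic carbon. The nearest guide is an 8.7-fold lower number from compound 1 to compound 2 (0.94 log units; beyond the scatter), which shows that a swap on this same aromatic carbon can move the number, but it involves a different pair of groups and gives no direction for this swap. The other step, a 1.9-fold lower number from compound 2 to compound 3 (0.29 log units; within the scatter), reflects the fact that compounds 2 and 3 differ only in the configuration as drawn and does not bear on it. The expected result is a 1.1-fold higher number from compound 2 to compound 4 (0.05 log units; within the scatter), which is no step beyond the scatter. The estimated value for compound 4 is 14000 nM, within a range of 5000 nM to 40000 nM.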

Compound 4, half-maximal inhibitory concentration: 51700 nM
Compound 4: middle estimate off by 3.7-fold (0.57 log units), on the low side; the measured number lies above the stated range.
By their numbers in this assay, from the lowest: compounds 3 and 2 (each within the scatter of the next); then compound 4; then compound 1.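

Replacing methoxy with fluoro on this aromatic carbon is not a neutral swap: it gives a 4.1-fold higher number from compound 2 to compound 4 (0.61 log units; beyond the scatter) and so separates two groups that had no measured comparison before. Fluoro still does better than isopropyl here, with a 2.1-fold lower number from compound 1 to compound 4 (0.33 log units; beyond the scatter) showing that the three groups give three distinct levels at this position. Nothing available on these compounds explains that order. On these data alone, whether a chloro or an amino group on the same carbon would fall inside this spread stays open. So does whether fluoro keeps its place in the configuration of compound 3.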